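The source may hold more compounds than are shown below. What is called first, only, known or untested is meant among the compounds shown, and "the series" means these compounds.

Measured in a functional assay on A549 cells (Homo sapiens) for antiproliferative activity, read by MTT assay, with a stated time of 72 h; on this read-out higher numbers stand for weaker inhibition and lower numbers for stronger inhibition:
- compound 1 `COc1cc2ncnc(Nc3cccc(Cl)c3)c2cc1OCCCN1CCNCCNCCNCC1` gives 27100 nM
- compound 2 `COc1cccc(Nc2ncnc3cc(OC)c(OCCCN4CCNCCNCCNCC4)cc23)c1` gives > 50000 nM, which is a limit and not a number
- compound 3 `COc1cc2ncnc(Nc3cccc(F)c3)c2cc1OCCCN1CCNCCNCCNCC1` gives > 50000 nM, which is also a limit and not a number

Compound 3 therefore has no exact place on the scale of this assay and stands at the limit of > 50000 nM in this assay, at which 2 of the 3 values shown sit.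

Compound 4 `COc1cc2ncnc(Nc3ccc(Cl)cc3Cl)c2cc1OCCCN1CCNCCNCCNCC1` keeps the shared core and the long side chain but carries 2,4-dichlorophenyl in place of 3-fluorophenyl on a nitrogen on an aromatic ring.

For the measured compounds named here, two measured steps bear on this change. Fluoro in place of chloro gives an at least 1.8-fold higher number from compound 1 to compound 3 (0.26 log units; that floor lies within the scatter), and methoxy in place of chloro gives an at least 1.8-fold higher number from compound 1 to compound 2 (0.26 log units; that floor lies within the scatter). Both are only floors, so they offer a weak hint and no firm size. Still, the one exact number among these compounds belongs to a chloro compound, since compound 1 gives 27100 nM. Going by the values given here, no measured step shows what a second chlorine does.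

A modest move toward stronger inhibition is therefore expected, although another limit remains quite possible. The expected change is an at least 2.0-fold lower number from compound 3 to compound 4 (0.30 log units; that floor lies within the scatter). For compound 4 the estimated value is 25000 nM, within an expected range of 10000 nM to 50000 nM.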

Compound 4, half-maximal inhibitory concentration: 23800 nM
Compound 4: middle estimate off by 1.1-fold (0.02 log units), on the high side, and the stated range covers the measured number.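

In this assay, for the compounds shown here, changing the aryl group on this nitrogen gives the first steps that lie beyond the scatter: 2,4-dichlorophenyl in place of 3-fluorophenyl gives an at least 2.1-fold lower number from compound 3 to compound 4 (0.32 log units; beyond the scatter), and 2,4-dichlorophenyl in place of 3-methoxyphenyl gives an at least 2.1-fold lower number from compound 2 to compound 4 (0.32 log units; beyond the scatter). Both steps are floors rather than full sizes, since each starts from a limit and not from a number: the limit of > 50000 nM in this assay, at which 2 of the 4 values shown sit. Compared with 3-chlorophenyl, however, 2,4-dichlorophenyl gives a 1.1-fold lower number from compound 1 to compound 4 (0.06 log units; within the scatter), so the two chlorine-bearing compounds cannot be told apart here, and among these four compounds only they give exact numbers, while the fluoro and methoxy compounds stay at the limit.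

As far as these compounds go, it remains open whether one of the two chlorines of 2,4-dichlorophenyl would be enough alone, and whether bromo or trifluoromethyl on the same ring would serve as well as chlorine. From the compounds shown here alone, it is also open whether the same ranking would hold if a shorter chain ending in a simple amine replaced the long side chain.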